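The source may hold more compounds than are shown below. What is called first, only, known or untested is meant among the compounds shown, and "the series" means these compounds.

In a physicochemical assay for lipophilicity (on this read-out lower numbers stand for lower lipophilicity and higher numbers for higher lipophilicity), compound 2 (`CN1CCN(c2ccc3ncc(-c4cnc(Nc5ncccc5F)nc4)n3n2)CC1`) reads 2.2 and stands highest of the two measured compounds, while compound 1 (`N[C@H]1CC[C@H](Nc2ccc3ncc(-c4cnc(Nc5ncc(C(F)(F)F)cc5F)nc4)n3n2)CC1`) reads 1.6 as the lower number, a gap beyond the scatter. Compound 3 (`CN1CC[C@H](Oc2ccc3ncc(-c4cnc(Nc5ncccc5F)nc4)n3n2)C1`) carries (1-methylpyrrolidin-3-yl)oxy in place of 4-methylpiperazin-1-yl on an aromatic carbon. Among the compounds with values here, no measured pair shows this change alone, so the expectation remains loose. A modest fall in this assay is expected, with an estimated a number 0.40 log units lower from compound 2 to compound 3 (beyond the scatter) as the size of the step. Compound 3 is expected at 1.8 on this scale, with an estimated range from 1.3 to 2.3 around that middle.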

Compound 3, distribution coefficient: 1.5
For compound 3 the middle estimate is 0.30 log units above the measured one; measured number inside the range.
By their numbers in this assay, from the lowest: compounds 3 and 1 (each within the scatter of the next); then compound 2.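

Moving from 4-methylpiperazin-1-yl to (1-methylpyrrolidin-3-yl)oxy on this aromatic carbon gives, in this assay, a number 0.70 log units lower from compound 2 to compound 3 (beyond the scatter) and is the only single-place change shown. This shift beyond the scatter occurs although the two groups have the same counts of heavy atoms and hydrogen-bond acceptors. Nothing available accounts for the step.

The compounds leave open whether the step follows the oxygen link or the five-membered ring, which change together here. A (1-methylpiperidin-4-yl)oxy group at this place would separate the two.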